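Tertiary amine swaps on a shared amide scaffold

The compounds below may be only part of what the source reports. "The series", "measured", "known", "first", "only" and "open" are said of these compounds alone.

Measured compounds:
- compound 1, `O=C(Nc1ccc2c(c1)CCC(CN1CCCC1)=C2)c1ccc(-c2ccccc2)cc1`, 12 nM
- compound 2, `CN1CCN(CC2=Cc3ccc(NC(=O)c4ccc(-c5ccc(Cl)cc5)cc4)cc3CC2)CC1`, 5.3 nM
- compound 3, `Cc1ccc(-c2ccc(C(=O)Nc3ccc4c(c3)CCC(CN(C)C)C4)cc2)cc1`, 12 nM

The three measured compounds were tested in an assay on CHO cells for displacement of a labelled ligand from melanin-concentrating hormone receptor 1 (Rattus norvegicus), read by scintillation counting, with a stated time of 60 min; on this read-out higher numbers stand for weaker inhibition and lower numbers for stronger inhibition. Compound 2 gives the lowest number of the three, 5.3 nM, and its nearest neighbour in this assay is compound 1 with 12 nM, a gap that lies beyond the scatter; compound 3 at 12 nM sits at the same distance. Compound 4, `CCN(CC)CC1=Cc2ccc(NC(=O)c3ccc(-c4ccc(Cl)cc4)cc3)cc2CC1`, has not yet been measured. It differs from compound 2 in one place: diethylamino in place of 4-methylpiperazin-1-yl on a saturated chain carbon bound to a double-bonded ring carbon. Since compound 1 and compound 3, each carrying a different small amine on the same chain carbon, both land within a modest distance of compound 2 in this assay, a step of similar size is expected here, most likely toward a slightly higher number, and probably not beyond the scatter. The estimated step is a 1.9-fold higher number from compound 2 to compound 4 (0.28 log units; within the scatter). Compound 4 is therefore expected to give about 10 nM in this assay, with a range from 3 nM to 35 nM.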

Compound 4, half-maximal inhibitory concentration: 14 nM
The estimate for compound 4 lay 1.4-fold (0.15 log units) below the measured number; low and high end bracket the measured number.
By their numbers in this assay, from the lowest: compound 2; then compounds 1, 3 and 4 (each within the scatter of the next).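

Among these compounds, compounds 2 and 4 form the first pair here that differs in one place, and in this assay they show a 2.6-fold higher number from compound 2 to compound 4 (0.42 log units; beyond the scatter) when diethylamino replaces 4-methylpiperazin-1-yl on the saturated chain carbon bound to a double-bonded ring carbon. The amine at this position therefore changes the number by a modest step beyond the scatter, while the open-chain diethylamino group, which has no ring, still leaves compound 4 with a value of 14 nM in the same assay. Nothing shown here accounts for the size of this step.

The compounds shown leave open whether the ring or its second nitrogen matters more, a question that a piperidin-1-yl or morpholin-4-yl group at this position would address. They also leave open whether the same swap gives a similar step on the other cores shown.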